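Series notes: tetrazole ketones, stability in liver fraction

A few compounds are considered here, and "the series" means these few. Any claim that something is new, unique, unknown or untested is made for them only; others in the source may bear on it.

Measured compounds:
compound 1 `CC(Oc1ccc(Oc2ccc(C(F)(F)F)cc2)cc1)C(=O)Cn1nnc(-c2ccc(Cl)cc2)n1`: 9%
compound 2 `CC(Oc1ccc(-c2ccccc2)cc1)C(=O)Cn1nnc(-c2ccc(Cl)cc2)n1`: 18%

In an ADME assay on S9 fraction from liver (Rattus norvegicus) for metabolic stability, read by LC-MS, using NADPH, with a stated time of 30 min (a higher number here means that more of the compound is left, a lower number that less of the compound is left), compound 1 gives 9%, the lowest of the two numbers; compound 2 gives 18%, and the step of a number 9 percentage points higher from compound 1 to compound 2 (within the scatter) lies within the scatter, so the two values cannot be ranked.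

Compound 3 `CC(Oc1ccc(Oc2ccc(C(F)(F)F)cc2)cc1)C(=O)Cn1nnc(-c2ccc(C(=O)O)cc2)n1` is not yet measured. It differs from compound 1 by carboxy in place of chloro on an aromatic carbon. Among the measured compounds shown here, no measured step touches this position: the only known step, a number 9 percentage points higher from compound 1 to compound 2 (within the scatter), changes the other end of the shared core and stays within the scatter. Nothing in the measured pair tells how an exchange of chloro for carboxy moves this assay.

For compound 3 the expectation therefore stays near compound 1, with a wide range: an estimated 15% (between 3% and 40%). The step this implies, a number 6 percentage points higher from compound 1 to compound 3 (within the scatter), is expected to lie within the scatter.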

Compound 3, percent of the compound remaining: 36%
For compound 3 the middle estimate is 21 percentage points below the measured one, within the range that was stated.
By their numbers in this assay, from the lowest: compounds 1 and 2 (each within the scatter of the next); then compound 3.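

In this assay, among the compounds shown here, the end of the shared core that carries the 4-chlorophenyl group is the first place where a change gives a step that can be read: 4-carboxyphenyl in place of 4-chlorophenyl gives a number 27 percentage points higher from compound 1 to compound 3 (beyond the scatter) and so counts as a modest step. The one earlier step, at the other end of the core, stayed within the scatter, so this position is the only one shown so far to move the read-out. This holds only with the 4-(trifluoromethyl)phenoxy group in place, and nothing at hand bears on the reason for the step.

On these data alone, it remains open whether the step belongs to the carboxylic acid itself or would also appear with a primary amide, a nitrile or a hydroxymethyl group at the same place. As far as these compounds go, it also remains open whether the same exchange would hold on compound 2, which carries phenyl at the other end.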